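Dropping the hydroxy from a bromophenyl hydrazone

A few compounds are considered here, and "the series" means these few. Any claim that something is new, unique, unknown or untested is made for them only; others in the source may bear on it.

Measured so far:
compound 1 `COc1ccc(/C=N/NC(=O)Nc2ccc(Oc3ccnc(-c4nncn4CCN(C)C)c3)c(F)c2)c(OC)c1`: 1570 nM
compound 2 `CN(C)CCn1cnnc1-c1cc(Oc2ccc(NC(=O)N/N=C/c3ccc(O)c(Br)c3)cc2F)ccn1`: 430 nM
compound 3 `CN(C)CCn1cnnc1-c1cc(Oc2ccc(NC(=O)N/N=C/c3cccc(Cl)c3Cl)cc2F)ccn1`: 72 nM

In a functional assay on NCI-H460 cells (Homo sapiens) for cytotoxicity, read by MTT assay, with a stated time of 72 h (a higher number here means a weaker inhibitor, a lower number a stronger inhibitor), compound 2 holds the second highest of the three numbers. Compound 1 lies nearest, as a 3.7-fold lower number from compound 1 to compound 2 (0.56 log units; beyond the scatter) shows, and compound 3 furthest, as a 6.0-fold lower number from compound 2 to compound 3 (0.78 log units; beyond the scatter) shows. Compound 4 `CN(C)CCn1cnnc1-c1cc(Oc2ccc(NC(=O)N/N=C/c3cccc(Br)c3)cc2F)ccn1` keeps the core of compound 2 and differs only in this: hydrogen in place of hydroxy on an aromatic carbon. Within the data shown here, no measured step removes a hydroxy alone. The step of a 6.0-fold lower number from compound 2 to compound 3 (0.78 log units; beyond the scatter) and the step of a 22-fold lower number from compound 1 to compound 3 (1.34 log units; beyond the scatter) both show that a phenyl carrying only halogens gives the lowest number here, so a modest lowering is expected in this assay. Compound 4 is therefore estimated at 200 nM, within 80 nM to 500 nM, which means an expected step of a 2.2-fold lower number from compound 2 to compound 4 (0.33 log units; beyond the scatter).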

Compound 4, half-maximal inhibitory concentration: 520 nM
The estimate for compound 4 lay 2.6-fold (0.41 log units) below the measured number; measured number above the stated range.
By their numbers in this assay, from the lowest: compound 3; then compounds 2 and 4 (each within the scatter of the next); then compound 1.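

Hydrogen and hydroxy cannot be told apart at this place in this assay, with a 1.2-fold higher number from compound 2 to compound 4 (0.08 log units; within the scatter). Carrying only a halogen is therefore not enough to reach the low number of compound 3, as a 7.2-fold higher number from compound 3 to compound 4 (0.86 log units; beyond the scatter) shows, even though the 3-bromophenyl group still compares well with 2,4-dimethoxyphenyl, with a 3.0-fold lower number from compound 1 to compound 4 (0.48 log units; beyond the scatter). No measurement shown here explains these results.

From the compounds shown here alone, whether an amine or a carboxylic acid at this place would also match hydrogen remains open. So does whether a chloro group in place of the bromo group of compound 4 would bring the number closer to that of compound 3.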